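The compounds below may be only part of what the source reports. "The series", "measured", "known", "first", "only" and "open" are said of these compounds alone.

Measured compounds:
Compound 1, `COc1ccc(/C=N/NC(=O)CSc2nnc(-c3ccncc3)o2)cc1` — 17600 nM
Compound 2, `O=C(CSc1nnc(-c2ccncc2)o1)N/N=C/c1cccc(C(F)(F)F)c1` — 14600 nM

Of the compounds shown here, two sharing the same core have been tested in a functional assay on MCF7 cells (Homo sapiens) for cytotoxicity, read by MTT assay, with a stated time of 48 h; on this read-out higher numbers stand for weaker inhibition and lower numbers for stronger inhibition. Compound 1 gives 17600 nM, and compound 2 gives 14600 nM. Compound 1 thus shows the higher of the two numbers, but its separation from compound 2 is within the usual scatter, so the two cannot be told apart on this read-out.

The third compound, compound 3, `O=C(CSc1nnc(-c2ccncc2)o1)N/N=C/c1cc(Cl)ccc1O`, has not yet been measured. It differs from compound 1 in one place: 5-chloro-2-hydroxyphenyl in place of 4-methoxyphenyl on a carbon with a double bond to nitrogen. Going by the values given here, no step between measured compounds covers this kind of change, so there is nothing in the numbers above to calibrate it. The two measured compounds carry quite different groups at this same position and still land within the scatter of each other, which suggests that a swap here may move this assay only modestly. A small shift toward a lower number is considered possible, though it may well stay within the scatter. The expected step of a 1.8-fold lower number from compound 1 to compound 3 (0.25 log units; within the scatter) is accordingly modest. Compound 3 is therefore estimated at 10000 nM, with a range from 3000 nM to 30000 nM.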

Compound 3, half-maximal inhibitory concentration: 5830 nM
Estimate against measurement, compound 3: 1.7-fold (0.23 log units) above; measured number inside the range.
By their numbers in this assay, from the lowest: compound 3; then compounds 2 and 1 (each within the scatter of the next).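

In this assay, putting 5-chloro-2-hydroxyphenyl in place of 4-methoxyphenyl on a carbon with a double bond to nitrogen gives a 3.0-fold lower number from compound 1 to compound 3 (0.48 log units; beyond the scatter), so a change at this position can move the read-out beyond the scatter, which the two earlier compounds, lying within the scatter of each other, could not show. The entering group brings a hydrogen-bond donor that the leaving group lacks, along with a chlorine in place of the methoxy carbon, so this one step carries several differences at once and cannot assign the shift to any one of them. Nothing measured on these compounds speaks to why the number drops.

The compounds shown leave open whether a phenyl carrying only the hydroxyl, or only the chlorine, would reproduce the lower number of compound 3. Also open, going by these compounds, is how an amine or a carboxylic acid at this same position would read in this assay, and whether a change elsewhere on the shared core would move the number as far as this step did.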